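Piperidine amide to imidazolyl amide: compound 2 to compound 4

This account rests on a few compounds, and the source may have more. Where it says the series, first, only, none or still open, it means among the compounds named here.

Compound 1 `O=C(Nc1ccc(C(F)(F)F)cc1)c1cccc(Nc2ncc(F)c(Nc3ccc(F)cc3)n2)c1`: > 10000 nM (a limit)
Compound 2 `CN1CCC(C(=O)Nc2cccc(Nc3ncc(F)c(Nc4ccc(F)cc4)n3)c2)CC1`: 1330 nM
Compound 3 `CN(C)c1ccc(C(=O)Nc2cccc(Nc3ncc(F)c(Nc4ccc(F)cc4)n3)c2)cc1`: > 10000 nM (a limit)

Going by the values given here, in a functional assay on A549 cells (Homo sapiens) for antiproliferative activity, read by sulforhodamine B assay, with a stated time of 3 days (on this read-out lower numbers stand for stronger inhibition of growth and higher numbers for weaker inhibition of growth), compound 2 gives 1330 nM, the only true number in the set. The values of compound 1 and compound 3 are limits. The next compound to be tested is compound 4 `Cn1ccnc1NC(=O)c1cccc(Nc2ncc(F)c(Nc3ccc(F)cc3)n2)c1`. The change is (1-methyl-1H-imidazol-2-yl)carbamoyl in place of ((1-methylpiperidin-4-yl)carbonyl)amino on an aromatic carbon.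

Among the compounds with values here, the one measured step that bears on this is an at least 7.5-fold higher number from compound 2 to compound 3 (0.87 log units; beyond the scatter), which also removes the 1-methylpiperidin-4-yl group. Its size is only a lower bound. A similar move towards weaker growth inhibition is expected here, given as a 3.8-fold higher number from compound 2 to compound 4 (0.58 log units; beyond the scatter). A reading at the limit of > 10000 nM in this assay, at which 2 of the 3 values shown sit, would not be surprising for compound 4. For compound 4 the estimated value is 5000 nM, with an expected range of 1500 nM to 12000 nM.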

Compound 4, concentration for 50% growth inhibition: 10100 nM
The estimate for compound 4 lay 2.0-fold (0.31 log units) below the measured number; measured number inside the range.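

In this assay, (1-methyl-1H-imidazol-2-yl)carbamoyl in place of ((1-methylpiperidin-4-yl)carbonyl)amino on this aromatic carbon gives a 7.6-fold higher number from compound 2 to compound 4 (0.88 log units; beyond the scatter). Compound 4 gives a true number, so one departure from the 1-methylpiperidin-4-yl amide now has a readable size rather than only a lower bound. Compound 1 and compound 3 remain limits, and the step from compound 1 to compound 4 cannot be read: the limit of > 10000 nM in this assay, at which 2 of the 4 values shown sit.

Compound 4 changes both the ring and the orientation of the amide, and the two effects remain unseparated. Open, from the compounds shown here alone, is whether a (1-methylpiperidin-4-yl)carbamoyl group or a cyclohexyl amide would retain the value of compound 2.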